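Thiourea series: from the ethyl chain to a longer one

This account rests on a few compounds, and the source may have more. Where it says the series, first, only, none or still open, it means among the compounds named here.

Compound 1 `Cc1ccc(NC(=S)Nc2cccc(C(F)(F)F)c2)cc1Cl`: 10000 nM
Compound 2 `CCNC(=S)Nc1cccc(C(F)(F)F)c1`: > 100000 nM

Both values come from an ADME assay on BHK cells (Mesocricetus auratus) for cytotoxicity, read by MTT assay, with a stated time of 96 h; on this read-out higher numbers stand for lower toxicity in this test and lower numbers for higher toxicity in this test. Compound 2 stands only at a limit of the assay, > 100000 nM, and not at a number.

Compound 3 `C=C(C)CNC(=S)Nc1cccc(C(F)(F)F)c1` carries 1-methylethenyl in place of methyl on a saturated chain carbon bound to an amide-type nitrogen. Going by the values given here, no measured step exists to scale this change, and the only numeric anchor is compound 1 at 10000 nM. A modest move toward lower numbers in this assay is expected, and compound 3 may again report only a limit. The expected change is an at least 1.4-fold lower number from compound 2 to compound 3 (0.15 log units; that floor lies within the scatter). For compound 3 the estimate is 70000 nM, with an expected range of 25000 nM to 150000 nM.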

Compound 3, half-maximal cytotoxic concentration: > 100000 nM
Compound 3 gave a limit, no number; the forecaster's own chance of this, stated with the estimate: 50%; at least 1.4-fold (0.15 log units) between middle value and limit.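

Compound 2 and compound 3 both stand only at a limit, so no step can be read between them: the limit of > 100000 nM in this assay, at which 2 of the 3 values shown sit.

Open remains what number either compound would give, and so whether 1-methylethenyl in place of methyl changes this read-out at all.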